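Chloro for Fluoro on Two Related Cores

The source may hold more compounds than are shown below. What is called first, only, known or untested is meant among the compounds shown, and "the series" means these compounds.

In a functional assay on HeLa cells (Homo sapiens) for cytotoxicity, read by MTT assay, with a stated time of 24 h (on this read-out higher numbers stand for weaker inhibition and lower numbers for stronger inhibition), three compounds have been measured so far.
Compound 1 `COc1cc(/C=C2\CN(C)C/C(=C\c3ccc(F)cc3)C2=O)cc(OC)c1OC` gives 7250 nM.
Compound 2 `COc1cc(/C=C2\CN(C)C/C(=C\c3ccc(Cl)cc3)C2=O)cc(OC)c1OC` gives > 20000 nM, which is a limit of the assay rather than a number.
Compound 3 `CN1C/C(=C\c2ccc(F)cc2)C(=O)/C(=C/c2ccc(C#N)cc2)C1` gives 10200 nM.

The change from compound 1 to compound 2 is chloro in place of fluoro on an aromatic carbon. This change gave an at least 2.7-fold higher number from compound 1 to compound 2 (0.44 log units; beyond the scatter), the value of compound 2 sitting at the limit of > 20000 nM in this assay, at which 1 of the 3 values shown sits. Compound 3 and compound 1 lie within the usual scatter of each other in this assay; how the core of compound 3 differs from the core of compound 1 is not broken down here. Compound 4 `CN1C/C(=C\c2ccc(Cl)cc2)C(=O)/C(=C/c2ccc(C#N)cc2)C1` has not yet been measured; relative to compound 3 it carries the same change, (chloro in place of fluoro on an aromatic carbon), at a place described in the same words. Because the earlier change read an at least 2.7-fold higher number from compound 1 to compound 2 (0.44 log units; beyond the scatter), the step from compound 3 to compound 4 is expected to be of comparable size, a 2.5-fold higher number from compound 3 to compound 4 (0.39 log units; beyond the scatter). Compound 4 is therefore estimated at 25000 nM. The range expected for compound 4 runs from 12000 nM to 60000 nM, and a result reported only as a limit would not surprise.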

Compound 4, half-maximal inhibitory concentration: 11200 nM
Estimate against measurement, compound 4: 2.2-fold (0.35 log units) above, and the stated range ends above it.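

In this assay, chloro in place of fluoro on the core bearing the nitrile gave a 1.1-fold higher number from compound 3 to compound 4 (0.04 log units; within the scatter), so on this core the change left the read-out within the scatter. Set beside the step on the core bearing the trimethoxyphenyl group, the two readings stand as follows: the same change on two cores in this assay, an at least 2.7-fold higher number (0.44 log units; beyond the scatter) from compound 1 to compound 2 and a 1.1-fold higher number (0.04 log units; within the scatter) from compound 3 to compound 4; the limit leaves it open whether they differ. Going by these compounds, compound 2 gives > 20000 nM, a limit and not a number, so the true size of the step on that core stays unknown, and the pair of steps neither shows nor rules out that the change carries from one core to the other.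

The compounds shown leave open how a bromo group, an amine or a carboxylic acid in the place of the halogen would read in this assay. Also open, on these data alone, are how a longer chain in place of the methyl group shared by all four compounds would read, and how the same change would behave on a third core.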